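One Ring Exchanged on Sulfur in Compound 2

The compounds below may be only part of what the source reports. "The series", "measured", "known", "first", "only" and "open" are said of these compounds alone.

In a functional assay on PC-3 cells (Homo sapiens) for inhibition, read by MTT assay, with a stated time of 72 h (a lower number here means a stronger inhibitor, a higher number a weaker inhibitor), compound 1 `FC(F)(F)c1ccc(CSc2nc(N3CCNCC3)cc(C(F)(F)F)n2)cc1` gives 15900 nM, and compound 2 `Cc1csc(Sc2cc(C(F)(F)F)nc(SCc3ccc(C(F)(F)F)cc3)n2)n1` gives 12000 nM. These two numbers lie within the usual scatter of each other, so compound 2 stands level with compound 1. Compound 3 `FC(F)(F)c1ccc(CSc2nc(Sc3ncccn3)cc(C(F)(F)F)n2)cc1` keeps the rest of compound 2 and carries pyrimidin-2-yl in place of 4-methyl-1,3-thiazol-2-yl on a sulfur. No measurement tests this exchange directly. For the measured compounds named here, the only measured step that bears on it, a 1.3-fold lower number from compound 1 to compound 2 (0.12 log units; within the scatter), brought in the (4-methyl-1,3-thiazol-2-yl)sulfanyl group in place of piperazin-1-yl, and it stayed within the scatter. On that slim evidence, no change beyond the scatter is expected in this assay. The expected step is a 1.1-fold higher number from compound 2 to compound 3 (0.03 log units; within the scatter). Compound 3 is estimated at 13000 nM, with an expected range of 6000 nM to 30000 nM.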

Compound 3, half-maximal inhibitory concentration: > 50000 nM
Compound 3: no number, only a limit; the forecaster's own chance of this, stated with the estimate: 10%; middle value at least 3.8-fold (0.58 log units) away from the limit.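

In this assay, the ring on this sulfur matters: pyrimidin-2-yl in place of 4-methyl-1,3-thiazol-2-yl gives an at least 4.1-fold higher number from compound 2 to compound 3 (0.61 log units; beyond the scatter), a step beyond the scatter, even though the two groups match in heavy atoms, hydrogen-bond donors and hydrogen-bond acceptors. Compound 1 and compound 2 had suggested that this place on the core tolerates quite different groups, yet (pyrimidin-2-yl)sulfanyl in place of piperazin-1-yl gives an at least 3.1-fold higher number from compound 1 to compound 3 (0.49 log units; beyond the scatter), so not every group is equivalent here. Compound 3 carries only a limit, not a number: the limit of > 50000 nM in this assay, at which 1 of the 3 values shown sits.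

As far as these compounds go, the full size of both steps therefore stays open. Also open, from the compounds shown here alone, is whether the 4-methyl-1,3-thiazol-2-yl group owes its place to its methyl or to its ring, which a plain 1,3-thiazol-2-yl or a phenyl ring on the same sulfur would help to separate.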